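Cyclopropylethynyl analogue in the adenosine A3 series

The source may hold more compounds than are shown below. What is called first, only, known or untested is meant among the compounds shown, and "the series" means these compounds.

Compound 2 `CNC(=O)[C@@]12C[C@@H]1[C@@H](n1cnc3c(NC)nc(C#Cc4cccnc4)nc31)[C@H](O)[C@@H]2O` gives 2.15 nM in an assay on CHO cells for displacement of a labelled ligand from adenosine receptor A3 (Homo sapiens), read by scintillation counting, with a stated time of 60 min; on this read-out lower numbers stand for stronger inhibition and higher numbers for weaker inhibition; among the three compounds measured it carries the highest number. Compound 1 `CNC(=O)[C@@]12C[C@@H]1[C@@H](n1cnc3c(NC)nc(C#Cc4ccccc4OC)nc31)[C@H](O)[C@@H]2O` gives 0.77 nM and compound 3 `CCc1ccc(C#Cc2nc(NC)c3ncn([C@H]4[C@H](O)[C@H](O)[C@]5(C(=O)NC)C[C@H]45)c3n2)o1` gives 1.5 nM in this assay. The step of a 2.8-fold higher number from compound 1 to compound 2 (0.45 log units; beyond the scatter) is the only one beyond the scatter, while a 1.9-fold higher number from compound 1 to compound 3 (0.29 log units; within the scatter) and a 1.4-fold lower number from compound 2 to compound 3 (0.16 log units; within the scatter) stay within it. Compound 4 `CNC(=O)[C@@]12C[C@@H]1[C@@H](n1cnc3c(NC)nc(C#CC4CC4)nc31)[C@H](O)[C@@H]2O` differs from compound 2 by cyclopropyl in place of pyridin-3-yl on a triple-bonded carbon. Each measured step exchanges one ring for another on the triple-bonded carbon; none exchanges pyridin-3-yl for a three-membered non-aromatic ring of carbon only, so the measured steps bear on the present one only in showing that changes on the triple-bonded carbon have so far moved this assay by modest amounts at most. The expected step is a 1.2-fold higher number from compound 2 to compound 4 (0.07 log units; within the scatter), comparable to or smaller than the measured steps and leaning toward a higher number. For compound 4 the expected value is 2.5 nM with a range from 0.8 nM to 8 nM.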

Compound 4, inhibition constant: 1.15 nM
Beside the measured number, compound 4's estimate is 2.2-fold (0.34 log units) above it, within the range that was stated.
By their numbers in this assay, from the lowest: compounds 1, 4, 3 and 2 (each within the scatter of the next, the first and the last beyond it).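

Cyclopropyl on a triple-bonded carbon stays in the range set by the aromatic rings in this assay, with a 1.9-fold lower number from compound 2 to compound 4 (0.27 log units; within the scatter) and a 1.3-fold lower number from compound 3 to compound 4 (0.12 log units; within the scatter) and a 1.5-fold higher number from compound 1 to compound 4 (0.17 log units; within the scatter). Among these four compounds, then, an aromatic ring at this position is not needed for a number in this range, and neither is the hetero atom or hydrogen-bond acceptor of pyridin-3-yl, since a three-membered non-aromatic ring of carbon only serves as well. No available evidence explains this result.

Open, from the compounds shown here alone, is whether a group with no ring at all, such as a straight butyl chain, would stay in this range at the triple-bonded carbon. The same question stands for a terminal amine or carboxylic acid carried on such a chain.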